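The compounds below may be only part of what the source reports. "The series", "measured", "known", "first", "only" and "open" are said of these compounds alone.

Compound 2 `C=C(Br)C(=O)Nc1cccc(-c2cn3c(-c4ccc(OC)cc4)csc3n2)c1` and compound 1 `C=C(Br)C(=O)Nc1cccc(-c2cn3c(-c4ccc(Cl)cc4)csc3n2)c1` share one core. In a functional assay on L1210 cells (Mus musculus) for inhibition, read by cell counting, with a stated time of 2 days (a lower number here means a stronger inhibitor, a higher number a weaker inhibitor), compound 2 gives 200 nM, and compound 1 gives 1900 nM. The change between them, (chloro in place of methoxy on an aromatic carbon), made a 9.5-fold higher number from compound 2 to compound 1 (0.98 log units; beyond the scatter). Compound 3 `C=C(Br)C(=O)Nc1cccc(-c2cn3nc(-c4ccc(OC)cc4)sc3n2)c1` carries a different core, and the difference between the two cores is not broken down here; in this assay compound 3 gives 940 nM. Compound 4 `C=C(Br)C(=O)Nc1cccc(-c2cn3nc(-c4ccc(Cl)cc4)sc3n2)c1` has not yet been measured. It differs from compound 3 by chloro in place of methoxy on an aromatic carbon, the same change that separates compound 2 from compound 1. Compound 4 is expected to show a step of similar size, a 7.4-fold higher number from compound 3 to compound 4 (0.87 log units; beyond the scatter), because a 9.5-fold higher number from compound 2 to compound 1 (0.98 log units; beyond the scatter) recorded this change on the other core. Compound 4 is accordingly estimated at 7000 nM, within a range from 2500 nM to 20000 nM.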

Compound 4, half-maximal inhibitory concentration: 1400 nM
Compound 4: the middle estimate sits 5.0-fold (0.70 log units) above what was measured; the whole stated range lies above it.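

In this assay, chloro in place of methoxy gave a 1.5-fold higher number from compound 3 to compound 4 (0.17 log units; within the scatter) on the core of compound 3, so on this core the change has no effect that can be told from the scatter. The size of the step therefore did not carry over from one core to the other: the same change on two cores in this assay, a 9.5-fold higher number (0.98 log units; beyond the scatter) from compound 2 to compound 1 and a 1.5-fold higher number (0.17 log units; within the scatter) from compound 3 to compound 4, 6.4-fold (0.80 log units) apart, beyond the scatter of two such steps. This shows that the step depends on the core for these two pairs, but it does not show which feature of the cores matters or how the change would behave on a third core. On these data alone, whether an amine or a fluoro in place of the methoxy would also differ between the two cores stays open. So does the role of the bromine on the amide side, which all four compounds share.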